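Swapping the bromophenyl arm of compound 1 for a catechol

This account rests on a few compounds, and the source may have more. Where it says the series, first, only, none or still open, it means among the compounds named here.

Among the compounds with values here, compound 1, `COc1cccc(/C=C2\CCC/C(=C\c3ccccc3Br)C2=O)c1OC`, stands at 12100 nM in a functional assay on SW-620 cells (Homo sapiens) for cytotoxicity, read by MTT assay, with a stated time of 72 h (a higher number here means a weaker inhibitor, a lower number a stronger inhibitor), the only numbered value among the two compounds so far measured. Compound 2, `COc1ccccc1/C=C1\CCC/C(=C\c2cccc(OC)c2OC)C1=O`, reaches only the limit of the assay in this assay, > 20000 nM; that value is a limit, not a number, as set out in the limit of > 20000 nM in this assay, at which 1 of the 2 values shown sits. Within the data shown here, the one measured step, an at least 1.6-fold higher number from compound 1 to compound 2 (0.21 log units; that floor lies within the scatter), thus shows a weakening that cannot be sized beyond its floor.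

Compound 3, `COc1cccc(/C=C2\CCC/C(=C\c3ccc(O)c(O)c3)C2=O)c1OC`, differs from compound 1 in this way: 3,4-dihydroxyphenyl in place of 2-bromophenyl on a double-bonded chain carbon bound to a double-bonded ring carbon. The measured step replaced one small substituent with another on the same arm, whereas here the whole aryl group changes, so that step bears on the new change only loosely. Among the measured compounds shown here, no measured compound carries hydroxyl groups, so the data give no direct guide for the size or direction of the step in this assay, and a step within the scatter is the most defensible expectation, with the limit result of compound 2 warning that a weakening is possible.

Compound 3 is therefore estimated at 9000 nM, within 2500 nM to 25000 nM. The expected step is a 1.3-fold lower number from compound 1 to compound 3 (0.13 log units; within the scatter).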

Compound 3, half-maximal inhibitory concentration: 6300 nM
The estimate for compound 3 lay 1.4-fold (0.15 log units) above the measured number; the range from low to high includes it.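

In this assay, the arm on the double-bonded chain carbon bound to a double-bonded ring carbon accepts a complete change of aryl group: with 3,4-dihydroxyphenyl in place of 2-bromophenyl, hydrogen-bond donors enter and the result stays within the scatter (a 1.9-fold lower number from compound 1 to compound 3 (0.28 log units; within the scatter)). Within the data shown here, measured against the 2-methoxyphenyl arm, the same 3,4-dihydroxyphenyl group gives the first step in this set that is beyond the scatter (an at least 3.1-fold lower number from compound 2 to compound 3 (0.50 log units; beyond the scatter)). That step can be read only as a floor, because compound 2 stands at a limit of the assay and not at a number: the limit of > 20000 nM in this assay, at which 1 of the 3 values shown sits.

The compounds shown cannot tell whether both hydroxyl groups of compound 3 matter, or whether either one alone would serve as well as the pair. On these data alone, how an amine or a carboxylic acid on this arm would fare in this assay also remains open, as does whether any group here can move the number beyond the scatter from that of compound 1.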